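A few compounds are considered here, and "the series" means these few. Any claim that something is new, unique, unknown or untested is made for them only; others in the source may bear on it.

Measured compounds in this series:

Compound 1, `N#CC1=C(N)Oc2c(c3nc4ccccc4nc3c3ccccc23)C12C(=O)N(Cc1cnnn1-c1ccc(F)cc1)c1ccccc12`. In an ADME assay on HUVEC cells (Homo sapiens) for antiproliferative activity, read by MTT assay, with a stated time of 48 h (on this read-out higher numbers stand for weaker inhibition and lower numbers for stronger inhibition), compound 1 gives > 50000 nM, which is a limit of the assay rather than a number.

Compound 2, `N#CC1=C(N)Oc2c(c3nc4ccccc4nc3c3ccccc23)C12C(=O)N(Cc1cnnn1-c1ccc(Cl)cc1)c1ccccc12`. In this assay compound 2 gives > 50000 nM, again a limit of the assay.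

Compound 3, `N#CC1=C(N)Oc2c(N)cc3nc4ccccc4nc3c2C12C(=O)N(Cc1cnnn1-c1ccc(F)cc1)c1ccccc12`. In this assay compound 3 gives > 50000 nM, also a limit of the assay.

Compound 1 and compound 2 differ in one place: chloro in place of fluoro on an aromatic carbon. The step that the two limits leave unreadable from compound 1 to compound 2 cannot be sized because of the limit of > 50000 nM in this assay, at which 3 of the 3 values shown sit. Compound 3 carries a different core from compound 1; the difference between the two cores is not broken down here.

Compound 4, `N#CC1=C(N)Oc2c(N)cc3nc4ccccc4nc3c2C12C(=O)N(Cc1cnnn1-c1ccc(Cl)cc1)c1ccccc12`, is not yet measured in this assay. It stands to compound 3 as compound 2 stands to compound 1: chloro in place of fluoro on an aromatic carbon. The descriptions of the place agree word for word between the two pairs, so this is the same change made a second time, now on the core of compound 3.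

What this change does in this assay is expected to stay small: the step that the limit leaves unreadable from compound 3 to compound 4 is estimated on the basis that the same change left compound 1 and compound 2 both at the limit, as the limit of > 50000 nM in this assay, at which 3 of the 3 values shown sit, records. Compound 4 is accordingly expected to give about 60000 nM, with an estimated range from 20000 nM to 200000 nM, and most probably to be reported only as a limit once more.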

Compound 4, half-maximal inhibitory concentration: > 50000 nM
Compound 4: a limit, no number; the forecaster's own chance of this, stated with the estimate: 85%; the middle value lies beyond the limit too.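

Compound 4 gives > 50000 nM in this assay as a limit of the assay and not a number. Among the compounds shown here, no step from compound 3 to compound 4 can be read, and the change from fluoro to chloro remains unsized on both cores: the limit of > 50000 nM in this assay, at which 4 of the 4 values shown sit.

The compounds shown leave open how the change from 4-fluorophenyl to 4-chlorophenyl acts on any value inside the measurable range of this assay.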